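The source may hold more compounds than are shown below. What is called first, only, known or untested is meant among the compounds shown, and "the series" means these compounds.

In a functional assay on DU-145 cells (Homo sapiens) for cytotoxicity, read by trypan blue exclusion, with a stated time of 96 h (on this read-out lower numbers stand for stronger inhibition and higher numbers for weaker inhibition), three compounds carrying a styryl sulfone have been measured. Compound 1, `COc1ccc(OC)c(/C=C/S(=O)(=O)Cc2ccc(OC)c(N)c2)c1`, gives 750 nM, and compound 2, `COc1ccc(N)cc1CS(=O)(=O)/C=C/c1c(OC)cccc1OC`, gives 25000 nM. Compound 3, `COC(=O)CCNc1cc(CS(=O)(=O)/C=C/c2c(OC)cc(OC)cc2OC)ccc1OC`, gives 1500 nM. That number lies within the usual scatter of compound 1 at 750 nM. The gap between that number and compound 2 at 25000 nM is well outside the usual scatter.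

Compound 4, `COC(=O)C(Nc1cc(CS(=O)(=O)/C=C/c2c(OC)cc(OC)cc2OC)ccc1OC)c1ccc(F)cc1`, has not yet been measured. It has (4-fluorophenyl)(methoxycarbonyl)methyl in place of 2-(methoxycarbonyl)ethyl on a nitrogen on an aromatic ring. The ester survives the change, but an aromatic ring is added to the group. Within the data shown here, no measured pair isolates a change of this kind, so the data give no direct guide to its size or direction. The expectation therefore starts from compound 3 at 1500 nM and allows a wide margin on both sides. The estimated outcome is a 1.5-fold lower number from compound 3 to compound 4 (0.18 log units; within the scatter), which is expected to stay within the scatter, with no clear direction. In this assay, compound 4 is expected to give about 1000 nM, with an estimated range from 200 nM to 5000 nM.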

Compound 4, half-maximal inhibitory concentration: 300 nM
Compound 4: middle estimate off by 3.3-fold (0.52 log units), on the high side, within the range that was stated.
By their numbers in this assay, from the lowest: compound 4; then compounds 1 and 3 (each within the scatter of the next); then compound 2.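

In this assay, among these compounds, the swap of 2-(methoxycarbonyl)ethyl for (4-fluorophenyl)(methoxycarbonyl)methyl on the nitrogen gives a 5.0-fold lower number from compound 3 to compound 4 (0.70 log units; beyond the scatter) and provides the first reading of a change at this position. The ester survives the change while a six-membered aromatic ring enters, and the number falls rather than rises, which shows that this place accepts the larger group. No measurement at hand bears on the reason for this fall.

Among the compounds shown here, the single step cannot separate the part played by the added ring from that of its fluorine, and a plain phenyl in place of the 4-fluorophenyl would be needed to do so. On these data alone, it also remains open whether the methyl ester matters here, or whether a carboxylic acid or an amide in its place would give a similar number.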